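Swapping methoxy for chloro on the aryl ring

This account rests on a few compounds, and the source may have more. Where it says the series, first, only, none or still open, it means among the compounds named here.

Compound 3 `C=C(Br)C(=O)Nc1cccc(-c2cn3nc(-c4ccc(OC)cc4)sc3n2)c1` stands second highest of the three numbers in a functional assay on CCRF-CEM cells (Homo sapiens) for inhibition, read by cell counting, with a stated time of 3 days (a higher number here means a weaker inhibitor, a lower number a stronger inhibitor), where it gives 1200 nM. Its nearest neighbour is compound 1 `C=C(Br)C(=O)Nc1cccc(-c2cn3nc(-c4ccc(C)cc4)sc3n2)c1`, which in this assay gives 1700 nM; the step of a 1.4-fold lower number from compound 1 to compound 3 (0.15 log units; within the scatter) lies within the scatter. Compound 2 `C=C(Br)C(=O)Nc1cccc(-c2cn3nc(-c4cccs4)sc3n2)c1` gives 410 nM in this assay, and the step of a 2.9-fold higher number from compound 2 to compound 3 (0.47 log units; beyond the scatter) is beyond the scatter. Compound 4 `C=C(Br)C(=O)Nc1cccc(-c2cn3nc(-c4ccc(Cl)cc4)sc3n2)c1` differs from compound 3 by chloro in place of methoxy on an aromatic carbon. Within the data shown here, no measured step exchanges methoxy for chloro; the only step on that six-membered ring, a 1.4-fold lower number from compound 1 to compound 3 (0.15 log units; within the scatter), was within the scatter, so a change of that order, or none beyond the scatter, is expected in this assay. Compound 4 is therefore estimated to give about 1000 nM, with a range of 400 nM to 2500 nM. This corresponds to an expected step of a 1.2-fold lower number from compound 3 to compound 4 (0.08 log units; within the scatter).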

Compound 4, half-maximal inhibitory concentration: 3200 nM
Estimate against measurement, compound 4: 3.2-fold (0.51 log units) below; measured number outside the range, above it.
By their numbers in this assay, from the lowest: compound 2; then compounds 3, 1 and 4 (each within the scatter of the next, the first and the last beyond it).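

In this assay, among these compounds, the group on this six-membered ring proves able to move the number: a 2.7-fold higher number from compound 3 to compound 4 (0.43 log units; beyond the scatter) is the first change there to go beyond the scatter, while a 1.9-fold higher number from compound 1 to compound 4 (0.27 log units; within the scatter) stays within it. Compound 2, with its thiophen-2-yl, remains apart from the three phenyl compounds, and a 7.8-fold higher number from compound 2 to compound 4 (0.89 log units; beyond the scatter) is the largest step in the set. Nothing available accounts for the difference between chloro and methoxy. Still open, as far as these compounds go, is how an amine or a carboxylic acid would behave at this place on the ring, and whether furan-2-yl would match thiophen-2-yl.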